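Second chloro on the 4-chlorophenyl compound

This account rests on a few compounds, and the source may have more. Where it says the series, first, only, none or still open, it means among the compounds named here.

In a functional assay on SEM cells (Homo sapiens) for cytotoxicity, with a stated time of 72 h (on this read-out higher numbers stand for an effect only at larger amounts of compound and lower numbers for an effect already at smaller amounts), compound 1 (`C=C[C@@](C)(/C=C/c1ccc(O)c(/C=C/C(=O)O)c1)CCC=C(C)C`) gives > 36600 nM, which is a limit and not a number. Compound 2 (`C=C[C@@](C)(/C=C/c1ccc(O)c(/C=C/c2ccc(Cl)cc2)c1)CCC=C(C)C`) gives > 36600 nM, likewise a limit. Compound 2 therefore has no numerical value and stands only at the limit of > 36600 nM in this assay, at which 2 of the 2 values shown sit. For the measured compounds named here, the only measured step is a step that the two limits leave unreadable from compound 1 to compound 2. It offers no size that can be carried forward.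

Compound 3 (`C=C[C@@](C)(/C=C/c1ccc(O)c(/C=C/c2ccc(Cl)c(Cl)c2)c1)CCC=C(C)C`) differs from compound 2 in one place: chloro in place of hydrogen on an aromatic carbon. The change takes 4-chlorophenyl to 3,4-dichlorophenyl, with the new chloro ortho to a chloro group and meta to a large group. Going by the values given here, no measured step covers this change, and no measured compound gives a number to start from.

Among the compounds with values here, the expectation in this assay is therefore weak: no large step, with at most a modest move toward lower numbers. Another limit remains the likelier report. The estimated step is an at least 1.2-fold lower number from compound 2 to compound 3 (0.08 log units; that floor lies within the scatter). For compound 3, the expected value is 30000 nM, with an estimated range of 12000 nM to 50000 nM.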

Compound 3, half-maximal effective concentration: > 7500 nM
Compound 3: no number, only a limit; the forecaster's own chance of this, stated with the estimate: 65%; the middle value lies beyond the limit too.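

In this assay compound 3 gives > 7500 nM, again a limit and not a number. For the compounds shown here, with only limits for compound 1, compound 2 and compound 3, no step among them can be read. Open is whether the added chloro, or any other change shown here, moves the read-out at all.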